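The source may report more compounds than this note shows. Statements on the series, on what has been measured and on what is new or still open speak of the compounds shown alone.

Working notes on the hydrazide series

The series is followed in an ADME assay on NL20 cells (Homo sapiens) for antiproliferative activity, read by MTT assay, with a stated time of 24 h; on this read-out higher numbers stand for weaker inhibition and lower numbers for stronger inhibition. Compound 1 `COc1cc(/C=C/C(=O)NNC(=O)c2ccccc2)ccc1O` gives 9550 nM in this assay. Compound 2 `O=C(/C=C/c1ccc(O)c(O)c1)NNC(=O)c1ccccc1` gives 8850 nM in this assay, and compound 3 `COc1ccc(C(=O)NNC(=O)/C=C/c2ccc(O)c(O)c2)cc1` gives 9390 nM in this assay. The three numbers sit close together: the step of a 1.1-fold lower number from compound 1 to compound 2 (0.03 log units; within the scatter) and the step of a 1.1-fold higher number from compound 2 to compound 3 (0.03 log units; within the scatter) are both within the scatter, so no ordering among compounds 1, 2 and 3 can be read from them.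

Compound 4 `COc1cc(/C=C/C(=O)NNC(=O)c2ccccc2)cc(OC)c1O` is not yet measured. It is reached from compound 1 by methoxy in place of hydrogen on an aromatic carbon. A change of the same kind has already been made once, from compound 2 to compound 3, as methoxy in place of hydrogen on an aromatic carbon; it gave the step of a 1.1-fold higher number from compound 2 to compound 3 (0.03 log units; within the scatter). The two cores differ by methyl in place of hydrogen on an oxygen on an aromatic ring. The surroundings of the change also differ: in compound 3 the entering methoxy sits para to a large group, whereas in compound 4 it sits ortho to a hydroxy group, meta to a large group and meta to a methoxy group. It is therefore the same kind of change, not the same change.

For the measured compounds named here, with that caution, the step from compound 1 to compound 4 is expected to be about a 1.0-fold lower number from compound 1 to compound 4 (0.00 log units; within the scatter) in this assay, resting on the single precedent from compound 2 to compound 3, which gave a 1.1-fold higher number from compound 2 to compound 3 (0.03 log units; within the scatter). For compound 4 the expected value is 9500 nM, with a range from 5000 nM to 18000 nM.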

Compound 4, half-maximal inhibitory concentration: > 10000 nM
Compound 4: no number, only a limit; the forecaster's own chance of this, stated with the estimate: 10%; middle value at least 1.0-fold (0.02 log units) from the limit.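

In this assay compound 4 gives > 10000 nM, which is a limit of the assay and not a number. The new step reads an at least 1.0-fold higher number from compound 1 to compound 4 (0.01 log units; that floor lies within the scatter), a floor and not a measured size, and set beside the earlier step it does not settle whether the methoxy change behaves alike on the two cores: the same change on two cores in this assay, a 1.1-fold higher number (0.03 log units; within the scatter) from compound 2 to compound 3 and an at least 1.0-fold higher number (0.01 log units; that floor lies within the scatter) from compound 1 to compound 4; the limit leaves it open whether they differ. As far as these compounds go, the core of compound 2 shows a step within the scatter for methoxy in place of hydrogen on an aromatic carbon, while the true size of the step on the core of compound 1 stays unknown, so carrying the change from one core to the other is neither confirmed nor refuted.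

The compounds shown leave open whether any change on these aromatic rings moves the result in this assay beyond the scatter, as three of the values lie within the scatter of each other and the fourth is a limit: the limit of > 10000 nM in this assay, at which 1 of the 4 values shown sits. They also leave open what an amine, a carboxylic acid or a longer chain would do in place of the methoxy on the core of compound 1.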